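Replacing thiophen-2-yl with 1,3-thiazol-2-yl in compound 2

A few compounds are considered here, and "the series" means these few. Any claim that something is new, unique, unknown or untested is made for them only; others in the source may bear on it.

Going by the values given here, in a functional assay on KB cells (Homo sapiens) for cytotoxicity (a lower number here means that less compound is needed, a higher number that more compound is needed for the effect), compound 1 (`COC1=C(C)C(=O)/C(=C(O)/C=C/c2ccco2)C(=O)C1(C)C`) gives 8.8 ug/mL, while compound 2 (`COC1=C(C)C(=O)/C(=C(O)/C=C/c2cccs2)C(=O)C1(C)C`) gives 3.4 ug/mL, the lower of the two numbers so far. Compound 3 (`COC1=C(C)C(=O)/C(=C(O)/C=C/c2nccs2)C(=O)C1(C)C`) has not yet been measured. It differs from compound 2 in one place: 1,3-thiazol-2-yl in place of thiophen-2-yl on a double-bonded chain carbon bound to a double-bonded chain carbon. In words, 1,3-thiazol-2-yl stands in place of thiophen-2-yl on a double-bonded chain carbon bound to a double-bonded chain carbon.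

Among the compounds with values here, one measured step bears on this, a ring exchange at the same place, furan-2-yl to thiophen-2-yl. It gave a 2.6-fold lower number from compound 1 to compound 2 (0.41 log units; beyond the scatter), modest but beyond the scatter. A single step offers no rule for the new ring, so only a small rise in this assay is expected, perhaps none beyond the scatter. The expected change is a 1.3-fold higher number from compound 2 to compound 3 (0.12 log units; within the scatter). For compound 3 the estimate is 4.5 ug/mL, with an expected range of 1.8 ug/mL to 11 ug/mL.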

Compound 3, concentration for half-maximal effect: 3 ug/mL
Compound 3: middle estimate off by 1.5-fold (0.18 log units), on the high side, and the stated range covers the measured number.
By their numbers in this assay, from the lowest: compounds 3 and 2 (each within the scatter of the next); then compound 1.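

In this assay the exchange gives a 1.1-fold lower number from compound 2 to compound 3 (0.05 log units; within the scatter) and so this place accepts 1,3-thiazol-2-yl, with its added ring nitrogen, about as well as thiophen-2-yl. The gap to furan-2-yl also holds for the new ring, which gives a 2.9-fold lower number from compound 1 to compound 3 (0.47 log units; beyond the scatter) and so, among these three compounds, the two rings that contain sulfur both stand apart from furan-2-yl, with no compound going against this. No measured evidence accompanies these numbers to explain that gap.

The compounds shown leave open how this place responds to a six-membered ring such as phenyl or pyridin-2-yl, or to an open chain such as butyl in place of the ring. They also leave open whether a small group on the ring, such as methyl or an amine, would move the number.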